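Working notes on compounds 1 to 3 in one cell assay

The compounds below may be only part of what the source reports. "The series", "measured", "known", "first", "only" and "open" are said of these compounds alone.

compound 1 `COc1cc(-c2cc(/C=C/C(=O)c3ccc(N)cc3)[nH]n2)cc(OC)c1OC`: 8400 nM
compound 2 `COc1ccc(-c2cc(/C=C/C(=O)c3ccc(N)cc3)[nH]n2)cc1OC`: 6480 nM

In a functional assay on ACHN cells (Homo sapiens) for inhibition, read by sulforhodamine B assay, with a stated time of 48 h (on this read-out lower numbers stand for higher toxicity in this test and higher numbers for lower toxicity in this test), compound 1 gives 8400 nM, the highest of the two numbers, and compound 2 gives 6480 nM; the step of a 1.3-fold lower number from compound 1 to compound 2 (0.11 log units; within the scatter) lies within the scatter. Compound 3 `COc1cc(-c2cc(/C=C/C(=O)c3ccc(F)c(F)c3)[nH]n2)cc(OC)c1OC` differs from compound 1 at the carbonyl carbon: 3,4-difluorophenyl in place of 4-aminophenyl on a carbonyl carbon. For the measured compounds named here, no measured step touches the ring on the carbonyl carbon; the only step known, a 1.3-fold lower number from compound 1 to compound 2 (0.11 log units; within the scatter), concerns the other ring and gives no guidance. Therefore no step beyond the scatter is expected, a 1.1-fold lower number from compound 1 to compound 3 (0.02 log units; within the scatter), with wide uncertainty. For compound 3 the expected value in this assay is 8000 nM, ranging from 2500 nM to 25000 nM.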

Compound 3, concentration lethal to 50% of the cells: > 100000 nM
Compound 3: only a limit was reported; the forecaster's own chance of this, stated with the estimate: 10%; middle value at least 12-fold (1.09 log units) away from the limit.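

In this assay compound 3 gives > 100000 nM, which is a limit of the assay and not a number: the limit of > 100000 nM in this assay, at which 1 of the 3 values shown sits. The ring on the carbonyl carbon is therefore not a silent position: 3,4-difluorophenyl in place of 4-aminophenyl gives an at least 11-fold higher number from compound 1 to compound 3 (1.07 log units; beyond the scatter), meaning lower toxicity in this test. The change on the other ring gave only a 1.3-fold lower number from compound 1 to compound 2 (0.11 log units; within the scatter).

The compounds shown do not separate loss of the amine from entry of the two fluorines. Going by these compounds, how 4-hydroxyphenyl or 4-(dimethylamino)phenyl would read at this position stays open, as does the size of the step beyond the limit.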